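A side-chain swap in a level series

This account rests on a few compounds, and the source may have more. Where it says the series, first, only, none or still open, it means among the compounds named here.

In a functional assay on PC-3 cells (Homo sapiens) for cytotoxicity, read by colorimetric assay and MTT assay (on this read-out higher numbers stand for weaker inhibition and lower numbers for stronger inhibition), the measured compounds read as follows:
compound 1 `CCN(CC)C(=O)Cn1c(=O)c(-c2ccc(OC)cc2)cc2c(OC)cc(OC)cc21` gives 10000 nM here
compound 2 `COc1ccc(-c2cc3c(OC)cc(OC)cc3n(CC#N)c2=O)cc1` gives 10000 nM here
compound 3 `COc1ccc(-c2cc3c(OC)cc(OC)cc3n(CC(=O)O)c2=O)cc1` gives 10000 nM here

Compound 3 stands level with compound 1 and compound 2 on these numbers. Compound 4 `COc1ccc(-c2cc3c(OC)cc(OC)cc3n(CCC#N)c2=O)cc1` keeps the shared core and differs in one group (cyanomethyl in place of carboxy on a saturated chain carbon bound to an aromatic nitrogen), with cyanomethyl in place of carboxy on a saturated chain carbon bound to an aromatic nitrogen. The nearest evidence is the exchange of cyano and carboxy at that place (no change at the digits printed from compound 2 to compound 3 (within the scatter)), and the other two steps (no change at the digits printed from compound 1 to compound 2 (within the scatter) and no change at the digits printed from compound 1 to compound 3 (within the scatter)) look the same. These steps in this assay all lie within the scatter, so the estimated change is none beyond it, in either direction (no change at the digits printed from compound 3 to compound 4 (within the scatter)). Compound 4 is estimated at 10000 nM with an expected range from 5000 nM to 20000 nM on this read-out.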

Compound 4, half-maximal inhibitory concentration: 10000 nM
For compound 4 middle estimate and measured number coincide at the digits printed, and the stated range covers the measured number.
By their numbers in this assay, from the lowest: compounds 1, 2, 3 and 4 (each within the scatter of the next).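

Cyanomethyl reads the same in this assay as each of the three groups tried earlier on a saturated chain carbon bound to an aromatic nitrogen (no change at the digits printed from compound 3 to compound 4 (within the scatter); no change at the digits printed from compound 2 to compound 4 (within the scatter); no change at the digits printed from compound 1 to compound 4 (within the scatter)). The series therefore stays level with a fourth group, which replaces a hydrogen-bond donor with none and a double bond with a triple bond. No measurement on hand accounts for this level reading.

On these data alone, whether any group at this place can shift the reading remains open. An amine, or a chain longer than 2-cyanoethyl, could test that.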